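The source may report more compounds than this note shows. Statements on the series, on what has been measured and on what is new or still open speak of the compounds shown alone.

Measured compounds:
compound 1 `CN(C)c1ncnc2[nH]cc(Sc3cccs3)c12`: 27500 nM
compound 2 `Nc1ncnc2[nH]cc(Sc3cccs3)c12`: > 50000 nM (a limit of the assay, not a number)

Going by the values given here, in a functional assay on HCT-116 cells (Homo sapiens), read by MTT assay, with a stated time of 3 days (on this read-out higher numbers stand for weaker inhibition and lower numbers for stronger inhibition), compound 1 gives 27500 nM, the only true number so far. Next comes compound 3 `c1coc(-c2ncnc3[nH]cc(Sc4cccs4)c23)c1`, with furan-2-yl in place of dimethylamino on an aromatic carbon of the shared core: furan-2-yl in place of dimethylamino on an aromatic carbon. Among the compounds with values here, only one measured step changes this same place, an at least 1.8-fold higher number from compound 1 to compound 2 (0.25 log units; that floor lies within the scatter). That step is bounded on one side only and brings in no ring, so it is weak guidance for the furan-2-yl group. With no firmer basis for a direction, the expected change is small: a 1.4-fold lower number from compound 1 to compound 3 (0.14 log units; within the scatter). The uncertainty remains wide on both sides. For compound 3 the estimated value in this assay is 20000 nM, with an expected range from 4000 nM to 50000 nM.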

Compound 3, half-maximal inhibitory concentration: 19500 nM
Beside the measured number, compound 3's estimate is 1.0-fold (0.01 log units) above it, and the stated range covers the measured number.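

Furan-2-yl on this aromatic carbon brings the first ring to this place and gives a 1.4-fold lower number from compound 1 to compound 3 (0.15 log units; within the scatter) in this assay, so exchanging dimethylamino for this larger ring group leaves the read-out within the scatter. Against amino, the same group gives an at least 2.5-fold lower number from compound 2 to compound 3 (0.40 log units; beyond the scatter), the first step at this place that lies beyond the scatter. That step is bounded on one side only, as compound 2 stands at a limit of the assay and not at a number: the limit of > 50000 nM in this assay, at which 1 of the 3 values shown sits.

Open, as far as these compounds go, is whether a phenyl group or a morpholine on the same carbon would move the number beyond the scatter from compound 1. Also open, from the compounds shown here alone, is how a longer chain or a carboxylic acid at this place would read in this assay.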